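This account rests on a few compounds, and the source may have more. Where it says the series, first, only, none or still open, it means among the compounds named here.

Working notes on the series. In an ADME assay on MT4 cells (Homo sapiens) for cytotoxicity, read by MTT assay, with a stated time of 5 days (a higher number here means that more compound is tolerated, a lower number that less compound is tolerated), compound 1 `N#Cc1ccc(Nc2nccc(OCC(=O)Nc3ccc(F)cc3)n2)cc1` gives only a limit, > 344000 nM. Compound 3 `N#Cc1ccc(NC(=O)COc2ccnc(Nc3ccc(C#N)cc3)n2)cc1` likewise gives only a limit, > 337000 nM, so its true position is not known. Compound 2 `N#Cc1ccc(Nc2nccc(OCC(=O)Nc3ccc(Cl)cc3)n2)cc1` gives a number, 162000 nM.

Compound 4 `COc1ccc(NC(=O)COc2ccnc(Nc3ccc(C#N)cc3)n2)cc1` differs from compound 3 by methoxy in place of cyano on an aromatic carbon, para to a large group. Three measured steps involve replacements of this kind. They are an at least 2.1-fold lower number from compound 1 to compound 2 (0.32 log units; beyond the scatter), an at least 2.0-fold higher number from compound 2 to compound 3 (0.31 log units; beyond the scatter) and a step that the two limits leave unreadable from compound 1 to compound 3. The first two are modest but beyond the scatter, and the third cannot be sized.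

Within the data shown here, no methoxy compound has been measured. Among the measured compounds shown here, the expectation therefore rests on compound 2, which at 162000 nM is the only number. A modest move to a lower number in this assay is expected, possibly not clearing the scatter. The estimated step is an at least 1.6-fold lower number from compound 3 to compound 4 (0.22 log units; that floor lies within the scatter). For compound 4 the expected value is 200000 nM, with an estimated range of 70000 nM to 360000 nM.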

Compound 4, half-maximal cytotoxic concentration: > 333000 nM
Compound 4: only a limit was reported; the forecaster's own chance of this, stated with the estimate: 50%; middle value at least 1.6-fold (0.22 log units) away from the limit.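

In this assay compound 4 gives > 333000 nM as a limit only. Methoxy in place of chloro at this place, para to a large group, gives an at least 2.0-fold higher number from compound 2 to compound 4 (0.31 log units; beyond the scatter) and so leaves compound 2 as the only compound shown with a number, while methoxy, cyano and fluoro all end in limits. The steps from compound 3 and from compound 1 to compound 4 cannot be read, because both values in each pair are limits: the limit of > 333000 nM in this assay, at which 1 of the 4 values shown sits.

On these data alone, how far compound 1, compound 3 and compound 4 lie past their limits stays open, so no order among them can be given. Also open, as far as these compounds go, is whether an amine, a carboxylic acid or a longer chain such as ethoxy at this place would give a number, as compound 2 does.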